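The source may report more compounds than this note shows. Statements on the series, on what has been measured and on what is new or still open speak of the compounds shown alone.

The measured compounds in this set:

Compound 1, `CC(=O)OCCc1c(C)nc(Cl)nc1Cl`: > 100000 nM, which is a limit of the assay and not a number.
Compound 2, `COc1nc(C)c(CCOC(C)=O)c(OC)n1`: 44000 nM.
Compound 3, `Cc1nc(Cl)nc(Cl)c1CCCl`: 400 nM.

All three were tested in a functional assay on SW-620 cells (Homo sapiens) for antiproliferative activity, read by MTT assay, with a stated time of 24 h; a higher number here means a weaker inhibitor, a lower number a stronger inhibitor. Compound 1 sits at the limit of > 100000 nM in this assay, at which 1 of the 3 values shown sits. Compound 3 differs from compound 1 by chloro in place of acetoxy on a saturated chain carbon, two bonds along the chain from an aromatic carbon, and the step that this change made is an at least 250-fold lower number from compound 1 to compound 3 (2.39 log units; beyond the scatter). Compound 2 carries the same acetoxy group on the same saturated chain carbon as compound 1, but the difference between the two cores is not broken down here; of compound 2 one can only say that its number is the highest among the two numbers given.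

Compound 4, `COc1nc(C)c(CCCl)c(OC)n1`, remains to be measured in this assay. It differs from compound 2 by chloro in place of acetoxy on a saturated chain carbon, two bonds along the chain from an aromatic carbon, the same change that separates compound 1 from compound 3, at the same place. Set beside an at least 250-fold lower number from compound 1 to compound 3 (2.39 log units; beyond the scatter), the step from compound 2 to compound 4 is expected to be a 29-fold lower number from compound 2 to compound 4 (1.47 log units; beyond the scatter). Going by the values given here, that expectation rests on the single measured instance of the change and on the starting point of compound 2 at 44000 nM. Compound 4 is accordingly estimated at 1500 nM, with a likely range from 200 nM to 15000 nM.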

Compound 4, half-maximal inhibitory concentration: > 100000 nM
Compound 4 ended at the assay's limit (the forecaster's own chance of this, stated with the estimate: 5%); at least 66-fold (1.82 log units) between middle value and limit.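

In this assay compound 4 gives > 100000 nM, which is a limit of the assay and not a number. Chloro in place of acetoxy on a saturated chain carbon, two bonds along the chain from an aromatic carbon, gave an at least 2.2-fold higher number from compound 2 to compound 4 (0.35 log units; beyond the scatter), so the change did not carry over from the core of compound 1 to the core of compound 2 in either size or direction: the same change on two cores in this assay, an at least 250-fold lower number (2.39 log units; beyond the scatter) from compound 1 to compound 3 and an at least 2.2-fold higher number (0.35 log units; beyond the scatter) from compound 2 to compound 4, at least 560-fold (2.75 log units) apart, beyond the scatter of two such steps This rests on a single pair on each core, it does not show which part of the cores sets the outcome, and the exact size of each step stays unknown, since each has a limit at one end: the limit of > 100000 nM in this assay, at which 2 of the 4 values shown sit.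

The compounds shown leave open how the change would behave on a core that mixes the ring groups of compound 1 and compound 2. They also leave open whether an amine or a hydroxyl in the place of chloro, or a longer chain carrying the chloro, would follow compound 3 or compound 4.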